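Three Nucleosides at the Assay Ceiling, a Fourth Expected There

This account rests on a few compounds, and the source may have more. Where it says the series, first, only, none or still open, it means among the compounds named here.

The three measured compounds were tested in a functional assay on HFF cells (Homo sapiens) for inhibition; on this read-out lower numbers stand for stronger inhibition and higher numbers for weaker inhibition:

Compound 1 `CSc1nc2c(C)nsc2n1[C@@H]1O[C@H](CO)[C@@H](O)[C@@H]1O` gives > 100000 nM, which is a limit of the assay.
Compound 2 `CSc1nc2cnsc2n1[C@@H]1O[C@H](CO)[C@@H](O)[C@@H]1O` gives > 100000 nM, which is a limit of the assay.
Compound 3 `CSc1nc2c(C)nsc2n1[C@@H]1O[C@H](CO)[C@@H](O)[C@H]1O` gives > 100000 nM, which is a limit of the assay.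

Compound 2 differs from compound 1 by hydrogen in place of methyl on an aromatic carbon. The step that the two limits leave unreadable from compound 1 to compound 2 cannot be sized, since both values are limits; this rests on (the limit of > 100000 nM in this assay, at which 3 of the 3 values shown sit). Compound 3 differs from compound 1 in configuration only: the two compounds have the same atoms and bonds and differ only in configuration as drawn: 1 of 4 stereo elements differ; a stereocentre at a saturated ring carbon is drawn S in compound 1 and R in compound 3. The step that the two limits leave unreadable from compound 1 to compound 3 is equally unreadable, as the fact that compounds 1 and 3 differ only in the configuration as drawn sets the two apart without either giving a number.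

Compound 4 `CSc1nc2cnsc2n1[C@@H]1O[C@H](CO)[C@@H](O)[C@H]1O` has not yet been measured in this assay. It differs from compound 3 by hydrogen in place of methyl on an aromatic carbon. This is the same change as that made from compound 1 to compound 2, and its size there could not be read.

Since all three measured values sit at a limit, compound 4 is expected to be no different: the estimated step that the limit leaves unreadable from compound 3 to compound 4 rests on the limit seen for compound 3 at > 100000 nM and on the unreadable step that the two limits leave unreadable from compound 1 to compound 2. Compound 4 is estimated at 200000 nM, with a range from 100000 nM to 1000000 nM, and most probably the assay will again report only a limit.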

Compound 4, half-maximal inhibitory concentration: > 100000 nM
Compound 4 ended at the assay's limit (the forecaster's own chance of this, stated with the estimate: 90%); the middle value does not contradict the limit.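

In this assay compound 4 gives > 100000 nM, which is a limit of the assay. No size can be read for the steps to compound 4 from compound 3 or from compound 2, because each step joins two limits: the limit of > 100000 nM in this assay, at which 4 of the 4 values shown sit. The compounds shown leave open whether hydrogen in place of methyl, or the configuration at the saturated ring carbon, changes inhibition at all.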